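Adding a Chloro to the Benzyl Group of Compound 3

The compounds below may be only part of what the source reports. "The series", "measured", "known", "first", "only" and "open" are said of these compounds alone.

Compound 3 `CCCSc1nc(N/N=C(\C)c2ccccc2O)c2nnn(Cc3ccccc3)c2n1` gives 11000 nM in a functional assay on MCF7 cells (Homo sapiens) for antiproliferative activity, read by MTT assay, with a stated time of 72 h (a lower number here means a stronger inhibitor, a higher number a weaker inhibitor), the lowest of the two numbers shown. Compound 2 `CCCSc1nc(N/N=C(\C)c2ccccc2O)c2nnn(Cc3ccco3)c2n1` gives 29000 nM, the difference being a 2.6-fold lower number from compound 2 to compound 3 (0.42 log units; beyond the scatter). Compound 1 `CCCSc1nc(N/N=C(\C)c2ccc(OC)cc2)c2nnn(Cc3ccccc3)c2n1` gives > 64000 nM, which is a limit of the assay rather than a number. From there the step is an at least 5.8-fold lower number from compound 1 to compound 3 (0.76 log units; beyond the scatter). Compound 4 `CCCSc1nc(N/N=C(\C)c2ccccc2O)c2nnn(Cc3ccc(Cl)cc3)c2n1` differs from compound 3 by chloro in place of hydrogen on an aromatic carbon. Neither measured step touches this part of the molecule: one alters the group on the carbon with a double bond to nitrogen, the other puts phenyl in place of furan-2-yl on the saturated chain carbon. No step beyond the scatter is therefore expected, and compound 4 is estimated at 10000 nM, between 4000 nM and 25000 nM. The expected step is a 1.1-fold lower number from compound 3 to compound 4 (0.04 log units; within the scatter).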

Compound 4, half-maximal inhibitory concentration: 42600 nM
Beside the measured number, compound 4's estimate is 4.3-fold (0.63 log units) below it; measured number outside the range, above it.
By their numbers in this assay, from the lowest: compound 3; then compounds 2 and 4 (each within the scatter of the next). At a limit, above all of these: compound 1.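

The benzyl group is a place where a single atom matters: in this assay, chloro in place of hydrogen, para to a large group, gives a 3.9-fold higher number from compound 3 to compound 4 (0.59 log units; beyond the scatter). The advantage phenyl held over furan-2-yl does not survive this chloro, as the step to 4-chlorophenyl reads a 1.5-fold higher number from compound 2 to compound 4 (0.17 log units; within the scatter). Nothing measured here accounts for this loss.

Open, going by these compounds, is whether a methoxy, an amine or a carboxylic acid on this same ring carbon would move the number as chloro does. Also open, on these data alone, is whether a longer chain in place of benzyl would restore activity.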